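Turning One Stereocentre of Compound 3

This account rests on a few compounds, and the source may have more. Where it says the series, first, only, none or still open, it means among the compounds named here.

In a functional assay on CCRF-CEM cells (Homo sapiens) for cytotoxicity (a higher number here means a weaker inhibitor, a lower number a stronger inhibitor), compound 3 (`C=C1C(=O)O[C@H]2C[C@H](C)C3=C(C[C@H]12)[C@]1(C)C[C@@H]3C[C@@]12C(=O)O[C@@H]1C[C@@]3(C)[C@@H](O)C[C@@H](O)C(=C)[C@@H]3C[C@@H]12`) gives 140 nM and stands level with compound 1 (`C=C1C(=O)O[C@H]2C[C@@H](C)C3=C(C[C@H]12)[C@@]1(C)C[C@@H]3C[C@@]12C(=O)O[C@@H]1C[C@@]3(C)[C@@H](O)C[C@@H](O)C(=C)[C@@H]3C[C@@H]12`) at 140 nM on these numbers, together the lowest of the three, while compound 2 (`C=C1C(=O)O[C@H]2CC(C)[C@@]34C[C@@H](C=C3C[C@H]12)[C@@]1(C4)C(=O)O[C@H]2CC(=C)[C@H]3CC[C@@](C)(O)[C@@H]3C[C@@H]21`) gives 2030 nM and is clearly weaker. Compound 4 (`C=C1C(=O)O[C@H]2C[C@H](C)C3=C(C[C@H]12)[C@@]1(C)C[C@@H]3C[C@@]12C(=O)O[C@@H]1C[C@@]3(C)[C@@H](O)C[C@@H](O)C(=C)[C@@H]3C[C@@H]12`) shows the two compounds have the same atoms and bonds and differ only in configuration as drawn: 1 of 12 stereo elements differ; a stereocentre at a saturated ring carbon is drawn S in compound 3 and R in compound 4 and nothing more: a stereocentre at a saturated ring carbon is drawn S in compound 3 and R in compound 4. Given the fact that compounds 1 and 3 differ only in the configuration as drawn as the closest guide, the one measured step shows no change at the digits printed from compound 1 to compound 3 (within the scatter) even though two stereo elements differ there. No step beyond the scatter is therefore expected, in either direction. The expected size is a 1.1-fold higher number from compound 3 to compound 4 (0.03 log units; within the scatter) in this estimate. For this assay compound 4 is expected at 150 nM with a range from 60 nM to 400 nM around it.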

Compound 4, half-maximal inhibitory concentration: 140 nM
Beside the measured number, compound 4's estimate is 1.1-fold (0.03 log units) above it, within the range that was stated.
By their numbers in this assay, from the lowest: compounds 1, 3 and 4 (each within the scatter of the next); then compound 2.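

Compound 1 and compound 3 differ at two stereocentres, so their earlier match could have hidden two opposite effects that cancelled out. In this assay turning one centre gives no change at the digits printed from compound 3 to compound 4 (within the scatter) and turning the other alone gives no change at the digits printed from compound 1 to compound 4 (within the scatter) on the shared core. Neither single turn moves the number beyond the scatter, so no hidden cancellation appears here.

Only configuration varies among these three compounds. On these data alone, whether this tolerance holds when an amine or a carboxylic acid is carried at these ring carbons stays open.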